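The compounds below may be only part of what the source reports. "The series", "measured", "known", "first", "only" and "open" are said of these compounds alone.

The measurements come from a functional assay on the whole organism (strain CF-1) for inhibition, with Mus musculus as the target (on this read-out higher numbers stand for an effect only at larger amounts of compound and lower numbers for an effect already at smaller amounts), and read as follows:

compound 1 `Cc1nnc(CN(C)C)n1-c1ccc(Cl)cc1C(=O)c1ccccc1` gives 0.5 mg/kg
compound 2 `Cc1nnc(CN2CCCC2)n1-c1ccc(Cl)cc1C(O)c1ccccc1` gives 8 mg/kg; 32 mg/kg (2 entries)
compound 3 `Cc1nnc(CN2CCCC2)n1-c1ccc(Cl)cc1C(=O)c1ccccc1` gives 0.4 mg/kg

Compound 3 holds the lowest of the two single numbers in this assay, but its nearest neighbour is compound 1, and the step of a 1.3-fold lower number from compound 1 to compound 3 (0.10 log units; within the scatter) stays within the scatter, so the two cannot be placed in order. Compound 2 gives no single number; its repeated entries, (the several entries of compound 2 in this assay, 8 mg/kg; 32 mg/kg (2 entries)), show how far repeated measurements of this kind can spread.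

The step from compound 3 to compound 4 `CCNCc1nnc(C)n1-c1ccc(Cl)cc1C(=O)c1ccccc1` changes the same place that the step from compound 1 to compound 3 touched: ethylamino in place of pyrrolidin-1-yl on a saturated chain carbon bound to an aromatic carbon. The group that enters carries a hydrogen-bond donor where the group that leaves carries none, and the ring gives way to a chain.

Among the compounds with values here, the only measured step on this position, a 1.3-fold lower number from compound 1 to compound 3 (0.10 log units; within the scatter), is within the scatter. Within the data shown here, no step involving a hydrogen-bond donor at this place has been measured. On that basis no change beyond the scatter is expected in this assay. Compound 4 is therefore estimated to give 0.6 mg/kg, with a range from 0.2 mg/kg to 2 mg/kg. The step this estimate means, a 1.5-fold higher number from compound 3 to compound 4 (0.18 log units; within the scatter), is expected to stay within the scatter.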

Compound 4, dose for half-maximal effect: 0.2 mg/kg
Estimate against measurement, compound 4: 3.0-fold (0.48 log units) above; low and high end bracket the measured number.
By their numbers in this assay, from the lowest: compounds 4, 3 and 1 (each within the scatter of the next, the first and the last beyond it).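

Ethylamino in place of pyrrolidin-1-yl gives a 2.0-fold lower number from compound 3 to compound 4 (0.30 log units; within the scatter), so in this assay the ring at this place can give way to a chain carrying a hydrogen-bond donor with no change that can be read. Ethylamino in place of dimethylamino gives a 2.5-fold lower number from compound 1 to compound 4 (0.40 log units; beyond the scatter), the first step on a saturated chain carbon bound to an aromatic carbon that goes beyond the scatter, though only modestly, while compound 3 cannot be told apart from either of the others. So modest a step calls for caution, given how widely repeated entries of this kind can lie apart: the several entries of compound 2 in this assay, 8 mg/kg; 32 mg/kg (2 entries).

Within the data shown here, whether the hydrogen-bond donor itself goes with the lower number of compound 4 stays open, as ethylamino is the only group at this place that carries one, and a single chain cannot separate the donor from the other differences between the groups. As far as these compounds go, a primary amine, a longer chain such as propylamino, or a piperidine ring at this place would each bear on that question, and how far this position tolerates larger groups also remains open.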